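This account rests on a few compounds, and the source may have more. Where it says the series, first, only, none or still open, it means among the compounds named here.

Within the data shown here, in a functional assay (microsomes, liver) with Rattus norvegicus as the target (on this read-out lower numbers stand for stronger inhibition and higher numbers for weaker inhibition), compound 1 (`Cc1c(C)c2c(c(C)c1N)CC(C)(C)O2`) gives 760 nM, the highest of the three numbers measured so far and therefore the weakest inhibition among them. Compound 2 (`Cc1c(C)c2c(c(N)c1N)CC(C)(C)O2`) gives 300 nM and compound 3 (`Cc1c(C)c2c(c(C)c1N)CC(C)(CSc1ccccc1)O2`) gives 270 nM. Compound 4 (`Cc1c(C)c2c(c(C)c1N)C(C(C)C)C(C)(C)O2`) keeps the core of compound 1 with one change: isopropyl in place of hydrogen on a saturated ring carbon.

Among the measured compounds shown here, no measured step adds isopropyl, so the evidence is only indirect. The closer parallel is a 2.8-fold lower number from compound 1 to compound 3 (0.45 log units; beyond the scatter), where phenylsulfanyl replaces hydrogen on a saturated chain carbon bound to a saturated ring carbon. The other is a 2.5-fold lower number from compound 1 to compound 2 (0.40 log units; beyond the scatter), with amino in place of methyl on an aromatic carbon. Both steps are modest and both lower the number, so a modest step in the same direction is expected in this assay, although no real change remains possible. The step expected here is a 2.3-fold lower number from compound 1 to compound 4 (0.36 log units; beyond the scatter). For compound 4 the estimated value is 330 nM, with an expected range from 110 nM to 1000 nM.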

Compound 4, half-maximal inhibitory concentration: 290 nM
For compound 4 the middle estimate is 1.1-fold (0.06 log units) above the measured one, and the stated range covers the measured number.
By their numbers in this assay, from the lowest: compounds 3, 4 and 2 (each within the scatter of the next); then compound 1.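

On the saturated ring carbon next to the ring atom that bears two methyl groups, two ring bonds from the ring oxygen, isopropyl in place of hydrogen gives a 2.6-fold lower number from compound 1 to compound 4 (0.42 log units; beyond the scatter) in this assay. This is the first change shown on this ring carbon, and it shows that the number can also fall with a group of carbon alone, with no ring, no hydrogen-bond donors or acceptors and no net charge. Nothing available explains why the number falls at this position.

With isopropyl as the only group shown on this ring carbon, a single step cannot tell whether size or shape matters here. From the compounds shown here alone, it stays open how an ethyl group, a longer chain, an amine or a carboxylic acid at the same place would change the number.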